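The source may report more compounds than this note shows. Statements on the series, on what has been measured and on what is new or still open speak of the compounds shown alone.

Measured compounds:
compound 1 `Nc1ccc(S(=O)(=O)N2CCN(c3ncc(C(O)(C(F)(F)F)C(F)(F)F)cc3C#CCCO)CC2)cn1`: < 14 mL.min-1.g-1
compound 2 `Nc1ccc(S(=O)(=O)N2CCN(c3ncc(C(O)(C(F)(F)F)C(F)(F)F)cc3-c3ccncc3)CC2)cn1`: 15 mL.min-1.g-1

Compound 1 was measured in an ADME assay (liver) for metabolic stability, with Liver microsome (Homo sapiens) as the target, using microsomes and NADPH, with a stated time of 30 min, tested at 1 uM; on this read-out higher numbers stand for fast clearance and lower numbers for slow clearance. In that read-out compound 1 gives < 14 mL.min-1.g-1, which is a limit of the assay and not a number. Compound 2 in this assay gives 15 mL.min-1.g-1. Within the data shown here, the only step between the two measured compounds, an at least 1.0-fold higher number from compound 1 to compound 2 (0.02 log units; that floor lies within the scatter), lies within the usual scatter, and the limit of < 14 mL.min-1.g-1 in this assay, at which 1 of the 2 values shown sits, means that the exact size of this step is not known.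

Compound 3 `Nc1ccc(S(=O)(=O)N2CCN(c3ncc(C(O)(C(F)(F)F)C(F)(F)F)cc3-c3ccc4[nH]ncc4c3)CC2)cn1` has not yet been measured. It differs from compound 1 in one place: 1H-indazol-5-yl in place of 4-hydroxybut-1-yn-1-yl on an aromatic carbon. Among the measured compounds shown here, the one measured step of a comparable kind, a ring in place of the same chain, is an at least 1.0-fold higher number from compound 1 to compound 2 (0.02 log units; that floor lies within the scatter), so for compound 3 no movement beyond the scatter is expected. Compound 3 is therefore expected to give 18 mL.min-1.g-1 in this assay, with a range from 9 mL.min-1.g-1 to 40 mL.min-1.g-1. That expectation corresponds to an at least 1.2-fold higher number from compound 1 to compound 3 (0.10 log units; that floor lies within the scatter).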

Compound 3, intrinsic clearance in microsomes: 27 mL.min-1.g-1
Beside the measured number, compound 3's estimate is 1.5-fold (0.18 log units) below it; the measured number falls inside the stated range.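

With 1H-indazol-5-yl on this aromatic carbon, this assay shows an at least 1.9-fold higher number from compound 1 to compound 3 (0.28 log units; that floor lies within the scatter). The true size of that step cannot be read, because compound 1 sits at a limit of the assay and has no exact number: the limit of < 14 mL.min-1.g-1 in this assay, at which 1 of the 3 values shown sits. The comparison between the two ring-bearing compounds has no such limit and gives a 1.8-fold higher number from compound 2 to compound 3 (0.26 log units; within the scatter), so a second aromatic ring group at this position, now with a five-membered ring and a six-membered ring, does not separate from pyridin-4-yl on this read-out.

The compounds shown leave open whether a different kind of group on this carbon, such as an amine, a carboxylic acid or a longer chain, would shift clearance beyond the scatter. Also open, as far as these compounds go, is how far compound 1 truly lies from the two ring-bearing compounds.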